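The compounds below may be only part of what the source reports. "The series", "measured", "known", "first", "only" and "open" are said of these compounds alone.

Series notes, continued. The shared core of compound 3 `CCCc1nc(-c2ccccc2)c(CNCCCN2CCN(c3cccc(C)c3)CC2)o1` is read in an assay on HEK293 cells for inhibition of Voltage-dependent T-type calcium channel subunit alpha-1G (Homo sapiens), read by patch clamp (on this read-out lower numbers stand for stronger inhibition and higher numbers for weaker inhibition), where compound 3 gives 1190 nM. Among the measured compounds shown here, of the three numbers measured so far this is the lowest. For the measured compounds named here, compound 2 `CCCc1nc(-c2ccccc2)c(CNCCCN2CCN(c3cccc(C)c3C)CC2)o1` gives 1780 nM, and the one single-place change recorded, a 1.5-fold lower number from compound 2 to compound 3 (0.17 log units; within the scatter), lies within the scatter, so compound 2 and compound 3 cannot be placed in order. Compound 1 `CCCc1nc(-c2ccccc2)c(CNCCN2CCN(c3ccccc3Cl)CC2)o1` gives 4370 nM, a number beyond the scatter from compound 3, but compound 1 differs from compound 3 in more than one place, so its value shows only that the two sit apart.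

Compound 4 `CCCc1nc(-c2ccccc2)c(CNCCCN2CCN(c3ccc(C(F)(F)F)cc3)CC2)o1` is not yet measured. It differs from compound 3 by 4-(trifluoromethyl)phenyl in place of 3-methylphenyl on an amine nitrogen in a ring. Going by the values given here, no measured step puts a trifluoromethyl anywhere, and the only step touching the aromatic ring on the amine nitrogen is the removal of a methyl, which stayed within the scatter. Nothing measured therefore supports expecting a step beyond the scatter in either direction. The expected step is a 1.3-fold higher number from compound 3 to compound 4 (0.10 log units; within the scatter), essentially flat. Compound 4 is accordingly estimated at 1500 nM, with a range from 500 nM to 4500 nM that allows for the unknown effect of the new group.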

Compound 4, half-maximal inhibitory concentration: 7250 nM
The estimate for compound 4 lay 4.8-fold (0.68 log units) below the measured number; the measured number lies above the stated range.
By their numbers in this assay, from the lowest: compounds 3 and 2 (each within the scatter of the next); then compounds 1 and 4 (each within the scatter of the next).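

In this assay the aromatic group on the amine nitrogen in a ring can move the number beyond the scatter: with 4-(trifluoromethyl)phenyl entering, replacing 3-methylphenyl gives a 6.1-fold higher number from compound 3 to compound 4 (0.78 log units; beyond the scatter) and replacing 2,3-dimethylphenyl gives a 4.1-fold higher number from compound 2 to compound 4 (0.61 log units; beyond the scatter), both in the same direction. Among the compounds shown here, the only earlier step at this position, a 1.5-fold lower number from compound 2 to compound 3 (0.17 log units; within the scatter), removed a methyl and stayed within the scatter, so the flat picture holds for the two methyl-bearing phenyl groups but does not extend to every aromatic group at this place. Nothing available bears on the cause of the higher number.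

The change replaces the substituent and alters its place on the ring in one move, so the compounds shown leave open whether the trifluoromethyl itself or its location goes with the higher number; a methyl where the trifluoromethyl of compound 4 stands, or a trifluoromethyl where the methyl of compound 3 stands, would separate the two. Also open, on these data alone, is how a chlorine, a methoxy group or a nitrile in the same place on the phenyl would read on this core.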